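Compound 3 to compound 4: one more aryl exchange

The source may hold more compounds than are shown below. What is called first, only, known or untested is meant among the compounds shown, and "the series" means these compounds.

In a functional assay on A549 cells (Homo sapiens) for antiproliferative activity, read by MTT assay, with a stated time of 48 h (on this read-out lower numbers stand for stronger inhibition and higher numbers for weaker inhibition), compound 1 (`C/C(=C\CC/C(C)=C/CC[C@@H]1[C@@]2(C)CCC(=O)C(C)(C)[C@H]2CC[C@@]1(C)O)CC/C=C(\C)C(=O)OCc1cn(-c2ccc(C(F)(F)F)cc2)nn1`) gives > 150000 nM, which is a limit of the assay and not a number. Compound 2 (`C/C(=C\CC/C(C)=C/CC[C@@H]1[C@@]2(C)CCC(=O)C(C)(C)[C@H]2CC[C@@]1(C)O)CC/C=C(\C)C(=O)OCc1cn(-c2ccccc2[N+](=O)[O-])nn1`) gives > 150000 nM, also a limit. Compound 3 (`C/C(=C\CC/C(C)=C/CC[C@@H]1[C@@]2(C)CCC(=O)C(C)(C)[C@H]2CC[C@@]1(C)O)CC/C=C(\C)C(=O)OCc1cn(-c2ccccc2C)nn1`) gives > 150000 nM, again a limit. Among the measured compounds shown here, the series so far therefore stands at the limit of > 150000 nM in this assay, at which 3 of the 3 values shown sit, and compound 3 has no number of its own.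

Compound 4 (`C/C(=C\CC/C(C)=C/CC[C@@H]1[C@@]2(C)CCC(=O)C(C)(C)[C@H]2CC[C@@]1(C)O)CC/C=C(\C)C(=O)OCc1cn(-c2cccc(Cl)c2)nn1`) carries 3-chlorophenyl in place of 2-methylphenyl on an aromatic nitrogen.

The measured steps that bear on this change exchange the group at the same place: a step that the two limits leave unreadable from compound 1 to compound 2, a step that the two limits leave unreadable from compound 1 to compound 3 and a step that the two limits leave unreadable from compound 2 to compound 3. None of them has a readable size, so no size can be carried over. No step beyond the scatter is expected in this assay, and no direction is expected either. Another limit is the likeliest report.

Compound 4 is estimated at 200000 nM. The expected range for compound 4 runs from 100000 nM to 400000 nM. The expected change is a step that the limit leaves unreadable from compound 3 to compound 4.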

Compound 4, half-maximal inhibitory concentration: 147000 nM
Compound 4: middle estimate off by 1.4-fold (0.13 log units), on the high side, within the range that was stated.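

In this assay compound 4 gives 147000 nM, the only number of its own among the compounds shown, so 3-chlorophenyl on the aromatic nitrogen is the one aryl group here with a readable value. Against the other aryl groups the steps are an at least 1.0-fold lower number from compound 3 to compound 4 (0.00 log units; that floor lies within the scatter), an at least 1.0-fold lower number from compound 2 to compound 4 (0.00 log units; that floor lies within the scatter) and an at least 1.0-fold lower number from compound 1 to compound 4 (0.00 log units; that floor lies within the scatter), so no real gain from this exchange is shown. The position therefore still gives no readable trend: the limit of > 150000 nM in this assay, at which 3 of the 4 values shown sit.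

The steps among compound 1, compound 2 and compound 3 cannot be read, so the three aryl groups cannot be ranked against one another. On these data alone, whether an amine or a carboxylic acid on the phenyl ring, or a longer chain in place of that ring, would give a step beyond the scatter stays open.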